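Removing a Methoxy Group: Expected Effect on Growth Inhibition

The source may report more compounds than this note shows. Statements on the series, on what has been measured and on what is new or still open speak of the compounds shown alone.

Compound 1 `COc1ccc(/C=C/C(=O)/C=C/c2ccc(OCc3cn(CCCCCOc4cc(=O)oc5ccccc45)nn3)c(OC)c2)cc1OC` and compound 2 `COc1cccc(/C=C/C(=O)/C=C/c2ccc(OCc3cn(CCCCCOc4cc(=O)oc5ccccc45)nn3)c(OC)c2)c1` share one core; compound 2 carries hydrogen in place of methoxy on an aromatic carbon. In a functional assay on COLO 205 cells (Homo sapiens) for inhibition, read by sulforhodamine B assay, with a stated time of 48 h, tested at 50 uM (on this read-out lower numbers stand for less inhibition of growth and higher numbers for more inhibition of growth at the one concentration tested), compound 1 gives 43%, and compound 2 gives 34%. Compound 3 `COc1cccc(/C=C/C(=O)/C=C/c2ccc(OCc3cn(CCCCOc4cc(=O)oc5ccccc45)nn3)c(OC)c2)c1` stands on another core, and the difference between the two cores is not broken down here; in this assay compound 3 gives 46%. Compound 4 `COc1cc(/C=C/C(=O)/C=C/c2ccccc2)ccc1OCc1cn(CCCCOc2cc(=O)oc3ccccc23)nn1` has not yet been measured. It differs from compound 3 by hydrogen in place of methoxy on an aromatic carbon. This is the same kind of change as that between compound 1 and compound 2, though the surroundings differ: in compound 1 the leaving methoxy sits ortho to a methoxy group and para to a large group, whereas in compound 3 it sits meta to a large group. The earlier change gave a number 9 percentage points lower from compound 1 to compound 2 (within the scatter). A step of about that size is expected here as well, a number 8 percentage points lower from compound 3 to compound 4 (within the scatter), with some added uncertainty due to the different surroundings hydrogen in place of methoxy on an aromatic carbon describes. Compound 4 is estimated to give 38% in this assay, likely between 25% and 50%.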

Compound 4, percent growth inhibition at one concentration: 31%
Compound 4: the middle estimate sits 7 percentage points above what was measured; measured number inside the range.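

In this assay, replacing the methoxy of the 3-methoxyphenyl group with hydrogen gives a number 15 percentage points lower from compound 3 to compound 4 (beyond the scatter). Set beside the earlier case of the same change, the two steps cannot be told apart in size: the same change on two cores in this assay, a number 9 percentage points lower (within the scatter) from compound 1 to compound 2 and a number 15 percentage points lower (beyond the scatter) from compound 3 to compound 4, 6 percentage points apart, within the scatter of two such steps. On these two cores, then, the change points the same way and its size carries over as far as this assay can tell, but two pairs do not show that it would hold on other cores, and they say nothing about why growth inhibition falls.

The compounds shown leave open how a hydroxyl group, a chlorine atom or an amine would compare with methoxy and hydrogen on that ring. They also leave open whether the step would look the same with a longer chain, and every reading here comes from a single concentration on one cell line.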